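Chain length at the aryl ether oxygen

The source may report more compounds than this note shows. Statements on the series, on what has been measured and on what is new or still open speak of the compounds shown alone.

Measured compounds:
compound 1 `Cc1[nH]c(=O)n(C)c1-c1ccc(OC(C)C)cc1`: 20400 nM
compound 2 `CCCCCCCCCCCCCCCCCCc1ccc(-c2c(C)[nH]c(=O)n2C)cc1`: > 100000 nM
compound 3 `Cc1[nH]c(=O)n(C2CCCCC2)c1-c1ccc(OC(C)C)cc1`: 13000 nM

The read-out is a functional assay on brain (Rattus norvegicus, strain Wistar) for inhibition; on this read-out higher numbers stand for weaker inhibition and lower numbers for stronger inhibition. For compound 2 the result is a limit of this assay, not a number (the limit of > 100000 nM in this assay, at which 1 of the 3 values shown sits). Among the two numbers, compound 3 stands lowest, with compound 1 nearest; the only step between measured compounds, a 1.6-fold lower number from compound 1 to compound 3 (0.20 log units; within the scatter), lies within the scatter.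

Compound 4 `CCCCCCCOc1ccc(-c2c(C)[nH]c(=O)n2C2CCCCC2)cc1` is not yet measured in this assay. It differs from compound 3 in one place: heptyl in place of isopropyl on an oxygen on an aromatic ring. Among the compounds with values here, no measured step changes the group on this oxygen, so none bears directly on it; compound 1 and compound 3 both carry isopropyl there, and compound 2 carries no oxygen at all. Within the data shown here, with no guiding step, the expectation for compound 4 is a number near that of compound 3, with wide uncertainty, expected as a 1.5-fold higher number from compound 3 to compound 4 (0.19 log units; within the scatter). Compound 4 is therefore estimated at 20000 nM, expected between 6000 nM and 70000 nM.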

Compound 4, half-maximal inhibitory concentration: 11600 nM
Estimate against measurement, compound 4: 1.7-fold (0.24 log units) above; the measured number falls inside the stated range.
By their numbers in this assay, from the lowest: compounds 4, 3 and 1 (each within the scatter of the next). At a limit, above all of these: compound 2.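

In this assay the oxygen on the aromatic ring now has a step of its own (a 1.1-fold lower number from compound 3 to compound 4 (0.05 log units; within the scatter)), and on this read-out compound 3 and compound 4 cannot be told apart. With cyclohexyl on the aromatic nitrogen, the position therefore takes heptyl as well as isopropyl, a reading that rests on this single pair. Compound 2, which carries an octadecyl chain and no oxygen on the aromatic ring, gives a limit of the assay and not a number: the limit of > 100000 nM in this assay, at which 1 of the 4 values shown sits.

Open, as far as these compounds go, is whether a longer chain on this oxygen, such as dodecyl, or a chain ending in an amine or a carboxylic acid, would move the number beyond the scatter. Also open, from the compounds shown here alone, is whether heptyl reads the same with methyl on the aromatic nitrogen.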